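The source may hold more compounds than are shown below. What is called first, only, known or untested is meant among the compounds shown, and "the series" means these compounds.

Measured so far:
- compound 1 `Clc1ccc(C2CC(c3ccc4c(c3)OCCO4)=NN2c2ccccc2)cc1`: 38600 nM
- compound 2 `Fc1ccc(C2CC(c3ccc4c(c3)OCCO4)=NN2c2ccccc2)cc1`: 6050 nM
- compound 3 `Cc1ccc(C2CC(c3ccc4c(c3)OCCO4)=NN2c2ccccc2)cc1`: 2530 nM

In a functional assay on WM 266-4 cells (Homo sapiens) for antiproliferative activity, read by MTT assay, with a stated time of 24 h (a lower number here means a stronger inhibitor of growth, a higher number a weaker inhibitor of growth), compound 3 stands lowest of the three, and since its steps to both others lie beyond the scatter it is the strongest inhibitor of growth here: the step of a 2.4-fold lower number from compound 2 to compound 3 (0.38 log units; beyond the scatter) is modest, the step of a 15-fold lower number from compound 1 to compound 3 (1.18 log units; beyond the scatter) large, and the step of a 6.4-fold lower number from compound 1 to compound 2 (0.80 log units; beyond the scatter) sits between them. All three differ only in the group on the aromatic carbon para to the large group.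

Compound 4 `c1ccc(COc2ccc(C3CC(c4ccc5c(c4)OCCO5)=NN3c3ccccc3)cc2)cc1` changes that same position: benzyloxy in place of methyl on an aromatic carbon. The measured steps show that this position governs the readout over a wide span, but each of them swaps one small group for another; none brings in anything as large as the benzyloxy group, so they set the position's sensitivity without pointing a direction. The account therefore expects a step of a 2.0-fold higher number from compound 3 to compound 4 (0.30 log units; within the scatter) with wide uncertainty, leaning toward a weaker inhibitor of growth because the smallest group gave the lowest number in a 15-fold lower number from compound 1 to compound 3 (1.18 log units; beyond the scatter). Compound 4 is estimated at 5000 nM, within 1200 nM to 20000 nM.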

Compound 4, concentration for 50% growth inhibition: 1130 nM
Compound 4: the middle estimate sits 4.4-fold (0.65 log units) above what was measured; measured number below the stated range.
By their numbers in this assay, from the lowest: compound 4; then compound 3; then compound 2; then compound 1.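

In this assay, the position para to a large group takes benzyloxy, which brings a six-membered aromatic ring of its own, and the number still falls (a 2.2-fold lower number from compound 3 to compound 4 (0.35 log units; beyond the scatter)). Compound 4 is therefore the strongest inhibitor of growth of the four, its steps from the halogen compounds being larger (a 5.4-fold lower number from compound 2 to compound 4 (0.73 log units; beyond the scatter); a 34-fold lower number from compound 1 to compound 4 (1.53 log units; beyond the scatter)), and among these four compounds the number does not rise with the size of the group, since the largest group gives the lowest number and chloro the highest. No evidence available here bears on the reason for this result.

As far as these compounds go, it remains open whether the lower number goes with the ether oxygen or with the added ring, which methoxy or phenyl at this position would help separate. From the compounds shown here alone, how an amine or a carboxylic acid on the benzyl ring would read also stays open.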